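Notes on the step from compound 3 to compound 4

The compounds below may be only part of what the source reports. "The series", "measured", "known", "first", "only" and "open" are said of these compounds alone.

Compound 3 `CC(=O)N1CCOC(CNC(=O)c2ccncc2Nc2cc(-c3ccc4ccn(C)c4c3)c3nccnc3c2)C1` stands at 0.217 h in an ADME assay on microsomes from liver (Mus musculus, strain CD-1) for metabolic stability, read by LC-MS, tested at 2 uM (a higher number here means that the compound lasts longer, a lower number that the compound disappears faster), and lies within the scatter of both other measured compounds: compound 1 `Cn1cc(CNC(=O)c2ccncc2Nc2cc(-c3ccc4ccn(C)c4c3)c3nccnc3c2)cn1` at 0.267 h as a half-life and compound 2 `CC(=O)N1CCCC(NC(=O)c2ccncc2Nc2cc(-c3ccc4ccn(C)c4c3)c3nccnc3c2)C1` at 0.4 h as a half-life. Compound 4 `CN1CCC(CNC(=O)c2ccncc2Nc2cc(-c3ccc4ccn(C)c4c3)c3nccnc3c2)C1` differs from compound 3 by a single exchange, 1-methylpyrrolidin-3-yl in place of 4-acetylmorpholin-2-yl on a saturated chain carbon bound to an amide-type nitrogen. The measured steps at this amide-type nitrogen are a 1.5-fold higher number from compound 1 to compound 2 (0.18 log units; within the scatter) and a 1.2-fold lower number from compound 1 to compound 3 (0.09 log units; within the scatter) and also a 1.8-fold lower number from compound 2 to compound 3 (0.27 log units; within the scatter) and all of them stay within the scatter. Among the measured compounds shown here, no measured compound carries 1-methylpyrrolidin-3-yl, so these steps offer only a rough guide. In this assay the estimated change is a 1.2-fold higher number from compound 3 to compound 4 (0.06 log units; within the scatter) and no step beyond the scatter is expected in either direction. Compound 4 is estimated at 0.25 h with an expected range of 0.12 h to 0.5 h as a half-life.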

Compound 4, half-life: > 1 h
Compound 4: no number, only a limit (the forecaster's own chance of this, stated with the estimate: 2%); at least 4.0-fold (0.60 log units) between middle value and limit.
By their numbers in this assay, from the lowest: compounds 3, 1 and 2 (each within the scatter of the next). At a limit, above all of these: compound 4.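

In this assay compound 4 gives no number, only a limit of the assay: the limit of > 1 h in this assay, at which 1 of the 4 values shown sits.

All earlier steps at this amide-type nitrogen stayed within the scatter, whereas 1-methylpyrrolidin-3-yl in place of 4-acetylmorpholin-2-yl gives an at least 4.6-fold higher number from compound 3 to compound 4 (0.66 log units; beyond the scatter), and the other two comparisons give an at least 3.7-fold higher number from compound 1 to compound 4 (0.57 log units; beyond the scatter) and an at least 2.5-fold higher number from compound 2 to compound 4 (0.39 log units; beyond the scatter). This position can therefore move the half-life beyond the scatter, although the exchange from compound 3 alters the ring size, the ring oxygen and the acetyl group in one step, so it assigns the rise to none of these alone.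

The compounds shown leave open how far the half-life of compound 4 extends past its limit. They also leave open whether the rise persists with a pyrrolidine carrying acetyl on its nitrogen, or with a piperidine carrying methyl there.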